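The source may report more compounds than this note shows. Statements on the series, on what has been measured and on what is new or still open speak of the compounds shown alone.

Measured compounds:
compound 1, `COc1cc(NC(C)CCCNC(=O)Nc2ccc(Cl)c(C(F)(F)F)c2)c2ncccc2c1`: "not determined" (no result reported) in an ADME assay on L6 cells (Rattus norvegicus) for cytotoxicity, read by resazurin assay, with a stated time of 70 h; on this read-out lower numbers stand for stronger inhibition and higher numbers for weaker inhibition
compound 2, `COc1cc(NC(C)CCCNC(=O)NNC(=O)/C=C/c2ccc(OC)c(OC)c2)c2ncccc2c1`: 37000 nM

Compound 2 holds the only number shown in this assay; for compound 1 no result was reported. Compound 3, `COc1cc(NC(C)CCCNC(=O)NNC(=O)Nc2cccc(C(F)(F)F)c2)c2ncccc2c1`, has not yet been measured. It differs from compound 2 in one place: (3-(trifluoromethyl)phenyl)amino in place of 2-(3,4-dimethoxyphenyl)ethenyl on a carbonyl carbon. No step between two measured compounds is shown, so any expectation rests on compound 2 alone. A step of modest size toward lower numbers in this assay is expected, as a 1.9-fold lower number from compound 2 to compound 3 (0.27 log units; within the scatter). Compound 3 is therefore estimated at 20000 nM, within a range from 5000 nM to 80000 nM.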

Compound 3, half-maximal inhibitory concentration: 32100 nM
The estimate for compound 3 lay 1.6-fold (0.21 log units) below the measured number; the measured number falls inside the stated range.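

In this assay, placing (3-(trifluoromethyl)phenyl)amino instead of 2-(3,4-dimethoxyphenyl)ethenyl on the carbonyl carbon gives a 1.2-fold lower number from compound 2 to compound 3 (0.06 log units; within the scatter), so this read-out does not separate the two groups at this position. The exchange swaps 2 hydrogen-bond acceptors for 1 hydrogen-bond donor and removes the double bond outside the aromatic ring, yet the two numbers remain within the usual scatter. No supporting measurement is available to account for this result. On these data alone, whether a simple amine or a carboxylic acid on this carbonyl carbon would give a clearly different number remains open.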